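Shrinking the Amine Ring on Compound 2

The source may report more compounds than this note shows. Statements on the series, on what has been measured and on what is new or still open speak of the compounds shown alone.

Of the compounds shown here, three sharing one core have been tested in a functional assay on MGC-803 cells (Homo sapiens) for inhibition, read by sulforhodamine B assay; a higher number here means a weaker inhibitor, a lower number a stronger inhibitor. Compound 1, `Cc1ccc(NC2=CC(=O)c3nc4n(c3C2=O)[C@H]2OC[C@@H](O)[C@H]2OC4)cc1`, gives 1420 nM in this assay. Compound 3, `O=C1C=C(Nc2ccc(C(F)(F)F)cc2)C(=O)c2c1nc1n2[C@H]2OC[C@@H](O)[C@H]2OC1`, gives 2820 nM. Among the compounds with values here, the move a 2.0-fold higher number from compound 1 to compound 3 (0.30 log units; within the scatter) is the only fully measured step here, and it does not rise above the scatter. Compound 2, `O=C1C(N2CCCCC2)=CC(=O)c2c1nc1n2[C@H]2OC[C@@H](O)[C@H]2OC1`, carries a piperidin-1-yl group, and for it this assay reports only a limit, > 4000 nM. That result is the limit of > 4000 nM in this assay, at which 1 of the 3 values shown sits, so where compound 2 truly stands relative to compound 1 and compound 3 cannot be told from the numbers shown.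

Compound 4, `O=C1C(N2CCC2)=CC(=O)c2c1nc1n2[C@H]2OC[C@@H](O)[C@H]2OC1`, differs from compound 2 in one place: azetidin-1-yl in place of piperidin-1-yl on a double-bonded ring carbon. Within the data shown here, no measured step touches this kind of change; the one step that exists, a 2.0-fold higher number from compound 1 to compound 3 (0.30 log units; within the scatter), swaps a substituent on an aromatic carbon rather than the size of a ring bound through nitrogen, and it was within the scatter. With only a limit for compound 2, there is no number from which a step could be counted, so the expected step that the limit leaves unreadable from compound 2 to compound 4 amounts to an expectation of little movement. Compound 4 is therefore estimated at 5000 nM, within 2000 nM to 15000 nM, with a real chance that this assay again reports only a limit.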

Compound 4, half-maximal inhibitory concentration: > 16000 nM
Compound 4 gave a limit, no number (the forecaster's own chance of this, stated with the estimate: 65%); middle value at least 3.2-fold (0.50 log units) away from the limit.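

Within the data shown here, compound 2 and compound 4 each gave only a limit in this assay, so no step between them can be read. The compounds shown leave open where either compound truly stands, and whether azetidin-1-yl in place of piperidin-1-yl changes the result at all.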